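This account rests on a few compounds, and the source may have more. Where it says the series, first, only, none or still open, it means among the compounds named here.

In a functional assay on HCT-116 cells (Homo sapiens) for cytotoxicity, read by a luciferase reporter and CellTiter-Glo, with a stated time of 72 h (a lower number here means a stronger inhibitor, a higher number a weaker inhibitor), the record so far is thin. Compound 1 `COc1ccccc1C1=NN(c2ccc(Cl)cc2)C(c2ccc(Cl)cc2)C1` has no numerical result, and its entry reads "not determined" (no result reported). Going by the values given here, compound 2 `CC(C)(C)C1=NN(c2ccc(Cl)cc2)C(c2ccc(Cl)cc2)C1` gives 17300 nM, the only number available, so it cannot yet be ranked against any other compound. Compound 3 `CC(C)(C)C1=NN(c2ccc(Cl)cc2)C(c2ccc(Cl)c(Cl)c2)C1` has still to be measured. Its structure departs from that of compound 2 in one place: chloro in place of hydrogen on an aromatic carbon. This puts chloro in place of hydrogen on an aromatic carbon, ortho to a chloro group and meta to a large group, so that 4-chlorophenyl becomes 3,4-dichlorophenyl. Among the compounds with values here, no measured pair shows what such a change does in this assay, so the expectation rests on one number and on the modest size of the structural change. The expected change, a 1.6-fold lower number from compound 2 to compound 3 (0.20 log units; within the scatter), is a small move towards a stronger inhibitor, within the usual scatter, though a step in either direction cannot be excluded. Compound 3 is estimated at 11000 nM, with an expected range of 4500 nM to 27000 nM.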

Compound 3, half-maximal inhibitory concentration: 5300 nM
Compound 3: middle estimate off by 2.1-fold (0.32 log units), on the high side; low and high end bracket the measured number.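

Going by these compounds alone, the step gives the first reading of this position: in this assay, chloro in place of hydrogen on an aromatic carbon, ortho to a chloro group and meta to a large group, brings a 3.3-fold lower number from compound 2 to compound 3 (0.51 log units; beyond the scatter). Within the data shown here, the turn from 4-chlorophenyl to 3,4-dichlorophenyl therefore moves this series towards a stronger inhibitor by a modest but readable amount, which the single number for compound 2 could not show. Nothing available explains why the number falls with this change.

The compounds shown leave open whether chloro is particular in this result, or whether fluoro, methoxy, an amine or a carboxylic acid on the same aromatic carbon would move the number in the same direction, by a similar amount, or not at all. The part of the core that separates compound 1 from compound 2 also cannot be judged, since the entry for compound 1 reads "not determined" (no result reported) and offers no number to set against the others.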